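The source may hold more compounds than are shown below. What is called first, only, known or untested is meant among the compounds shown, and "the series" means these compounds.

Values in a physicochemical assay for lipophilicity (on this read-out higher numbers stand for higher lipophilicity and lower numbers for lower lipophilicity), stand as follows:
- Compound 1 `CCNC(=O)Nc1ccc(-c2nc(CS(C)(=O)=O)cc([C@]34CCOC[C@H]3C4)n2)cc1` gives 3.6
- Compound 2 `CCNC(=O)Nc1ccc(-c2nc(C(C)(C)S(C)(=O)=O)cc([C@]34CCOC[C@H]3C4)n2)cc1` gives 4.7
- Compound 3 `CCNC(=O)Nc1ccc(-c2nc(CS(C)(=O)=O)cc([C@@]34CCOC[C@@H]3C4)n2)cc1` gives 3.6

Compound 1 stands level with compound 3, the two sharing the lowest of the three numbers, while compound 2 lies furthest from it. Compound 4 `CNCC(=O)Nc1ccc(-c2nc(CS(C)(=O)=O)cc([C@]34CCOC[C@H]3C4)n2)cc1` keeps the core of compound 1 and has (methylamino)methyl in place of ethylamino on a carbonyl carbon. Neither measured step touches this place. The first, a number 1.10 log units higher from compound 1 to compound 2 (beyond the scatter), is large but comes from 1-methyl-1-(methylsulfonyl)ethyl in place of (methylsulfonyl)methyl on an aromatic carbon. The second, no change at the digits printed from compound 1 to compound 3 (within the scatter), goes with the fact that compounds 1 and 3 differ only in the configuration as drawn and so offers no guide to this change. The expectation therefore rests only on the counted change in hydrogen-bond acceptors, taken from compound 1 at 3.6 as the starting point. In this assay a modest downward step is expected (a number 0.60 log units lower from compound 1 to compound 4 (beyond the scatter)). For compound 4 the estimate is 3 with an expected range from 2.3 to 3.6 for the coming measurement.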

Compound 4, partition coefficient: 3.1
The estimate for compound 4 lay 0.10 log units below the measured number, within the range that was stated.
By their numbers in this assay, from the lowest: compound 4; then compounds 1 and 3 (each within the scatter of the next); then compound 2.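

In this assay, within the data shown here, the only measured change at this carbonyl carbon is (methylamino)methyl in place of ethylamino (a number 0.50 log units lower from compound 1 to compound 4 (beyond the scatter)), a place that neither earlier step touched. The two groups have the same heavy atoms and the same hydrogen-bond donor count, and differ by the hydrogen-bond acceptor counted for (methylamino)methyl, so a rearrangement of the same atoms at this place goes with a step beyond the scatter. Nothing available here explains that step.

From the compounds shown here alone, it remains open whether methoxymethyl or (dimethylamino)methyl on the same carbonyl carbon would move the number in the same direction. Going by these compounds, it is also open whether the step would carry over to compound 2, which bears 1-methyl-1-(methylsulfonyl)ethyl.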